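This account rests on a few compounds, and the source may have more. Where it says the series, first, only, none or still open, it means among the compounds named here.

Working notes on the series. Of the compounds shown here, three have been measured in an ADME assay on BV-2 cells (Mus musculus) for cytotoxicity, with a stated time of 24 h, tested at 10 uM; on this read-out higher numbers stand for a weaker effect at the one concentration tested and lower numbers for a stronger effect. Compound 1 `COc1ccccc1S(=O)(=O)/C=C/c1ncccc1F` gives 100% in this assay. Compound 2 `COc1cccc(S(=O)(=O)/C=C/c2ccc(Cl)cn2)c1` gives 100% in this assay. Compound 3 `COc1ccc(S(=O)(=O)/C=C/c2ccccn2)cc1` gives 100% in this assay. On these numbers compound 3 stands level with compounds 1 and 2 at the digits given: the gap to compound 1, the nearest, shows no change within the scatter, and the gap to compound 2, the furthest, likewise shows no change within the scatter. For the measured compounds named here, no pair of measured compounds differs in only one place, so no measured step is available to guide the next comparison.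

Compound 4 `COc1ccc(S(=O)(=O)/C=C/c2cccc(Cl)n2)cc1` has not yet been measured in this assay. Relative to compound 3 the change is chloro in place of hydrogen on an aromatic carbon of a six-membered aromatic ring with 1 nitrogen, next to the ring nitrogen and meta to a large group. The three measured values sit at one level across the three compounds, and nothing in them points to a step in either direction. For compound 4 the expected value in this assay is 100%, in the range 88% to 108%. Expected is no change at the digits printed from compound 3 to compound 4 (within the scatter), that is, no step beyond the scatter.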

Compound 4, a percentage reported as activity, at one concentration (the size of the read-out at that concentration, not a potency): 97%
Estimate against measurement, compound 4: 3 percentage points above; measured number inside the range.
By their numbers in this assay, from the lowest: compounds 4, 1, 2 and 3 (each within the scatter of the next).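

In this assay, for the compounds shown here, chloro in place of hydrogen on an aromatic carbon, next to the ring nitrogen and meta to a large group, gives a number 3 percentage points lower from compound 3 to compound 4 (within the scatter), and this is the first comparison between two compounds that differ in one place. Going by these compounds alone, it shows that this position takes a chloro group with no step beyond the scatter at the one concentration tested, something the earlier compounds, which differ in more than one place, could not show on their own. No measured evidence on the origin of this result is at hand.

The compounds shown leave open whether an amine, a carboxylic acid or a longer chain at this same place would also stay within the scatter of compound 3, since a chloro group is the only replacement for hydrogen that can be read here. Compounds 1 and 2 differ from compound 4 in more than one place, so they cannot show whether a halogen elsewhere on the ring would behave as this chloro group does.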